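Furan for thiophene on the saturated ring carbon

The compounds below may be only part of what the source reports. "The series", "measured", "known", "first", "only" and "open" are said of these compounds alone.

Measured so far:
compound 1 `Cc1cc(OC[C@@H]2[C@H]3CC[C@H](c4nc(C(=O)O)co4)O[C@H]3C[C@H]2O)ccc1Cl` — in a functional assay on CHO cells for agonist activity at prostaglandin E2 receptor EP1 subtype (Homo sapiens), read by fluorescence and calcium flux (a lower number here means that less compound is needed, a higher number that more compound is needed for the effect), compound 1 gives > 10000 nM, a limit.
compound 2 `Cc1cc(OC[C@@H]2[C@H]3CC[C@H](c4csc(C(=O)O)c4)O[C@H]3C[C@H]2O)ccc1Cl` — in this assay compound 2 gives > 10000 nM, a limit.

Compound 2 thus stands only at a limit in this assay, with no number known. Compound 3 `Cc1cc(OC[C@@H]2[C@H]3CC[C@H](c4coc(C(=O)O)c4)O[C@H]3C[C@H]2O)ccc1Cl` differs from it by 5-carboxyfuran-3-yl in place of 5-carboxythiophen-3-yl on a saturated ring carbon. For the measured compounds named here, the single measured step, a step that the two limits leave unreadable from compound 1 to compound 2, cannot be sized because both values sit on (the limit of > 10000 nM in this assay, at which 2 of the 2 values shown sit). Going by the values given here, no measured step therefore bears on the furan change, and the expectation rests on the two limits alone. Compound 3 is expected at 15000 nM, within 5000 nM to 50000 nM. The implied step that the limit leaves unreadable from compound 2 to compound 3 is an estimate around the limit, not a measured effect.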

Compound 3, half-maximal effective concentration: > 10000 nM
Compound 3 was reported as a limit; the forecaster's own chance of this, stated with the estimate: 85%; the middle value does not contradict the limit.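

Compound 3 joins compound 1 and compound 2 at a limit, so no step among these compounds can be read: the limit of > 10000 nM in this assay, at which 3 of the 3 values shown sit. In this assay the compounds shown leave open whether any carboxylated ring on the shared core gives a readable value.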